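Methyl for methoxy: metabolic stability working notes

The compounds below may be only part of what the source reports. "The series", "measured", "known", "first", "only" and "open" are said of these compounds alone.

Three compounds are measured in an ADME assay on liver (Mus musculus) for metabolic stability, read by LC-MS, using microsomes and NADPH; on this read-out higher numbers stand for a more stable compound and lower numbers for a less stable compound. Compound 1 `Cc1cc(CN(C2CCC2)C(CC(=O)O)c2ccc(Cl)cc2)ccc1OCCn1c(=O)ccn(C)c1=O` gives 22%. Compound 2 `COc1cc(CN(C2CCC2)C(CC(=O)O)c2ccc(Cl)cc2)ccc1OCCn1c(=O)ccn(C)c1=O` gives 51%. Compound 3 `COc1cc(CN(CC(C)C)C(CC(=O)O)c2ccc(Cl)c(F)c2)ccc1OCCN1C(=O)CCC1=O` gives 57%; its gap to compound 2 is within the scatter, its gap to compound 1 lies beyond it. The difference between the cores of compound 2 and compound 3 is not broken down here.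

The change from compound 2 to compound 1 is methyl in place of methoxy on an aromatic carbon and it made a number 29 percentage points lower from compound 2 to compound 1 (beyond the scatter).

Compound 4 `Cc1cc(CN(CC(C)C)C(CC(=O)O)c2ccc(Cl)c(F)c2)ccc1OCCN1C(=O)CCC1=O` is not yet measured in this assay. It differs from compound 3 by methyl in place of methoxy on an aromatic carbon, the same kind of change as before: here the carbon is ortho to a 2-(2,5-dioxopyrrolidin-1-yl)ethoxy group rather than ortho to a large group, while in both cases it is meta to a large group. Among the compounds with values here, only that one earlier instance of the change exists, and the expectation rests on it. The expected step is a number 25 percentage points lower from compound 3 to compound 4 (beyond the scatter), set beside the earlier one and widened in its range for resting on a single pair. Compound 4 is accordingly estimated at 32%, with a range from 15% to 50%.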

Compound 4, percent of the compound remaining: 33%
For compound 4 the middle estimate is 1 percentage points below the measured one; the range from low to high includes it.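

In this assay, methyl in place of methoxy on an aromatic carbon again lowers the read-out, here as a number 24 percentage points lower from compound 3 to compound 4 (beyond the scatter). Across the two cores, the step keeps its direction and shows no difference in size that can be told from the scatter: the same change on two cores in this assay, a number 29 percentage points lower (beyond the scatter) from compound 2 to compound 1 and a number 24 percentage points lower (beyond the scatter) from compound 3 to compound 4, 5 percentage points apart, within the scatter of two such steps

These two pairs support carrying the change between these two cores only; they do not show why the read-out falls, nor that a step of this size would hold on any other core in the series.

The compounds shown carry only methoxy or methyl at this aromatic carbon, so the result with an ethoxy group or a hydroxyl group there remains open. All four compounds also keep the carboxylic acid, which leaves open whether the step would persist on a compound with a primary amide in its place.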